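This account rests on a few compounds, and the source may have more. Where it says the series, first, only, none or still open, it means among the compounds named here.

Measured compounds:
Compound 1 `O=c1cc(-c2ccccc2)oc2cc(O)c(OCCCN3CCCCC3)c(O)c12` — in a functional assay on A549 cells (Homo sapiens) for antiproliferative activity, read by MTT assay, with a stated time of 48 h (a lower number here means a stronger inhibitor, a higher number a weaker inhibitor), compound 1 reaches only a limit, > 100000 nM.
Compound 2 `O=c1cc(-c2ccccc2)oc2cc(OCc3ccccc3)c(OCCCCN3CCCCC3)c(O)c12` — in this assay compound 2 gives 1900 nM.
Compound 3 `O=c1cc(-c2ccccc2)oc2cc(OCc3ccccc3)c(OCCCN3CCCCC3)c(O)c12` — in this assay compound 3 gives 3100 nM.

Compound 2 and compound 3 sit within the scatter of each other, a 1.6-fold higher number from compound 2 to compound 3 (0.21 log units; within the scatter), so the two cannot be separated by this assay. Compound 1 yields only a limit. Among the measured numbers compound 2 is thus one of two that cannot be told apart, with the limit of compound 1 standing far away.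

The step to compound 4 `O=c1cc(-c2ccccc2)oc2cc(O)c(OCCCCN3CCCCC3)c(O)c12` is hydrogen in place of benzyl on an oxygen on an aromatic ring. Among the measured compounds shown here, one measured step bears directly on it, run in the opposite direction: an at least 32-fold lower number from compound 1 to compound 3 (1.50 log units; beyond the scatter), where benzyl entered on the same oxygen and the number fell from a limit to a measured value. Taking the benzyl off compound 2 is therefore expected to raise the number by a comparably large margin, and compound 4 would then land at the limit of > 100000 nM in this assay, at which 1 of the 3 values shown sits, where compound 1 already sits. The expected step is a 53-fold higher number from compound 2 to compound 4 (1.72 log units; beyond the scatter). Compound 4 is estimated at 100000 nM, with a range from 30000 nM to 300000 nM, and it is more likely than not that only a limit is reported.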

Compound 4, half-maximal inhibitory concentration: 75000 nM
The estimate for compound 4 lay 1.3-fold (0.12 log units) above the measured number; low and high end bracket the measured number.
By their numbers in this assay, from the lowest: compounds 2 and 3 (each within the scatter of the next); then compound 4. At a limit, above all of these: compound 1.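

Hydrogen in place of benzyl on an oxygen on an aromatic ring now has a size free of any limit: a 39-fold higher number from compound 2 to compound 4 (1.60 log units; beyond the scatter) in this assay. The change is large on both cores, those of the butyl-linked and propyl-linked piperidines, so this oxygen is the one place in the series where a large step has been seen: the same change on two cores in this assay, an at least 32-fold lower number (1.50 log units; beyond the scatter) from compound 1 to compound 3 and a 39-fold lower number (1.60 log units; beyond the scatter) from compound 4 to compound 2; the limit leaves it open whether they differ Without the benzyl, compound 4 gives 75000 nM as a measured number.

Compound 1 stands at a limit of the assay. Once the benzyl is gone, (piperidin-1-yl)methyl in place of piperidin-1-yl gives an at least 1.3-fold lower number from compound 1 to compound 4 (0.12 log units; that floor lies within the scatter) and so whether the chain matters then stays open: the same change on two cores in this assay, a 1.6-fold higher number (0.21 log units; within the scatter) from compound 2 to compound 3 and an at least 1.3-fold higher number (0.12 log units; that floor lies within the scatter) from compound 4 to compound 1; the limit leaves it open whether they differ Also open is what a methyl or a 4-fluorobenzyl on this oxygen would do to the number in this assay, and whether a morpholine or a dimethylamino group at the chain end would keep the values of the benzyl-bearing compounds.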